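This account rests on a few compounds, and the source may have more. Where it says the series, first, only, none or still open, it means among the compounds named here.

Of the compounds shown here, three that share one core have been measured in an assay on isolated protein for inhibition of solute carrier family 22 member 12 (Homo sapiens), tested at 3 uM; a lower number here means less inhibition, a higher number more inhibition at the concentration tested (going by the name of the read-out). Compound 1 `CCc1cc(C(=O)n2cccc2)cc(C#N)c1O` gives 83%. Compound 2 `CSc1cc(C(=O)N2CC=CC2)cc(C#N)c1O` gives 58%, and compound 3 `N#Cc1cc(C(=O)N2CC=CC2)cc(Cl)c1O` gives 66%. Among these three numbers compound 2 has the lowest; its gap to compound 3 lies within the scatter, while compound 1 stands beyond the scatter above it.

The step in view leads from compound 2 to compound 4 `N#Cc1cc(C(=O)N2CC=CC2)cc(Br)c1O`, which has not yet been measured. The change is bromo in place of methylsulfanyl on an aromatic carbon. The new group sits on an aromatic carbon of the six-membered aromatic ring, ortho to the hydroxy group and meta to the cyano group.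

For the measured compounds named here, one measured step bears directly on this: a number 8 percentage points higher from compound 2 to compound 3 (within the scatter), where chloro replaced the same methylsulfanyl at the same place. Bromo is another group of one heavy atom entering there, so a step of similar size, upward but small, is expected: a number 10 percentage points higher from compound 2 to compound 4 (within the scatter). Compound 4 is therefore estimated at 68%, with a likely range from 52% to 82%.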

Compound 4, a percentage reported as inhibition, at one concentration (the size of the read-out at that concentration, not a potency): 69%
Compound 4: the middle estimate sits 1 percentage points below what was measured; the range from low to high includes it.
By their numbers in this assay, from the lowest: compounds 2, 3 and 4 (each within the scatter of the next, the first and the last beyond it); then compound 1.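

In this assay, for the compounds shown here, bromo gives the first step at this aromatic carbon that clears the scatter: a number 11 percentage points higher from compound 2 to compound 4 (beyond the scatter). Chloro, by contrast, gave a number 8 percentage points higher from compound 2 to compound 3 (within the scatter), yet the two halogens cannot be told apart, with a number 3 percentage points higher from compound 3 to compound 4 (within the scatter), so the result separates bromo from methylsulfanyl but does not rank bromo above chloro. No measurement shown here gives a reason for the difference between these groups.

As far as these compounds go, what fluoro, methoxy or an amine would give on this same carbon remains open. Going by these compounds alone, also open is whether replacing methylsulfanyl with bromo would give a similar step when the carbonyl carries the group found in compound 1 rather than the one shared by compound 2 and compound 4.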